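Adding a chloro group to compound 3

This account rests on a few compounds, and the source may have more. Where it says the series, first, only, none or still open, it means among the compounds named here.

Measured compounds:
- Compound 1 `COc1ccc(/C=C2\N=C(c3ccc(C)cc3)N(C(=O)c3nc4c(c(C)nn4-c4ccccc4)c(=O)[nH]3)NC2=O)cc1` gives 37.7 nM
- Compound 2 `Cc1nn(-c2ccccc2)c2nc(C(=O)N3NC(=O)/C(=C/c4ccc(Cl)cc4)N=C3c3ccccc3)[nH]c(=O)c12` gives 28.1 nM
- Compound 3 `Cc1nn(-c2ccccc2)c2nc(C(=O)N3NC(=O)/C(=C/c4ccccc4)N=C3c3ccccc3)[nH]c(=O)c12` gives 14.7 nM

These numbers come from a functional assay on HCT-116 cells (Homo sapiens) for cytotoxicity, read by MTT assay, with a stated time of 48 h; on this read-out lower numbers stand for stronger inhibition and higher numbers for weaker inhibition. Compound 3 has the lowest number of the measured set. Its nearest neighbour is compound 2, and the step of a 1.9-fold lower number from compound 2 to compound 3 (0.28 log units; within the scatter) lies within the scatter of the assay, so the two cannot be told apart. Compound 1 stands further away, beyond the scatter, with compound 3 the stronger of the pair.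

Compound 4 `Cc1nn(-c2ccccc2)c2nc(C(=O)N3NC(=O)/C(=C/c4ccccc4)N=C3c3ccc(Cl)cc3)[nH]c(=O)c12` is the next step. It differs from compound 3 by chloro in place of hydrogen on an aromatic carbon; the group sits on the phenyl attached to the shared core, para to a large group.

Among the measured compounds shown here, only one measured step speaks to a chloro group on an aromatic carbon: the step of a 1.9-fold lower number from compound 2 to compound 3 (0.28 log units; within the scatter), where the chloro left a different phenyl ring and the number fell slightly, within the scatter. That step involves another ring, so it bears only loosely here. With so thin a basis, a change of comparable small size is expected for compound 4, perhaps a slightly higher number but not beyond the scatter.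

Compound 4 is therefore estimated at 20 nM, with a range from 9 nM to 45 nM, a step of a 1.4-fold higher number from compound 3 to compound 4 (0.13 log units; within the scatter).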

Compound 4, half-maximal inhibitory concentration: 13.9 nM
The estimate for compound 4 lay 1.4-fold (0.16 log units) above the measured number; the range from low to high includes it.
By their numbers in this assay, from the lowest: compounds 4, 3, 2 and 1 (each within the scatter of the next, the first and the last beyond it).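

In this assay, turning the phenyl into a 4-chlorophenyl, with the chloro para to a large group, gives a 1.1-fold lower number from compound 3 to compound 4 (0.02 log units; within the scatter), so this position takes a chloro with no change that the assay can detect. Among the compounds shown here, until now, the only step involving a chloro on an aromatic carbon was a 1.9-fold lower number from compound 2 to compound 3 (0.28 log units; within the scatter), on a different phenyl ring, and the new step shows that a chloro on this ring also stays within the scatter. Nothing available here explains why the number holds at this position, and a cell read-out of this kind cannot show it on its own.

From the compounds shown here alone, a single small atom is a narrow test of the position, so it remains open whether an amine, a carboxylic acid or a longer chain in the same place would leave the number as undisturbed as the chloro does. Also open, going by these compounds, is what a compound carrying a chloro on both phenyl rings would give, since each chloro has been seen only alone.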